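From compound 3 to compound 4: hydroxymethyl for cyclohex-1-en-1-yl

This account rests on a few compounds, and the source may have more. Where it says the series, first, only, none or still open, it means among the compounds named here.

In an ADME assay on MT4 cells (Homo sapiens) for cytotoxicity, read by MTT assay, with a stated time of 5 days (on this read-out higher numbers stand for lower toxicity in this test and lower numbers for higher toxicity in this test), compound 1 (`COc1cc2cc(C#N)ccc2c(OC)c1Oc1cc(NCC(C)(C)C)nc(Nc2ccc(C#N)cc2)n1`) gives > 125000 nM, which is a limit. Compound 2 (`CCCC(CCC)Nc1cc(Oc2c(OC)cc3cc(C#N)ccc3c2OC)nc(Nc2ccc(C#N)cc2)n1`) gives > 125000 nM, again a limit. Compound 3 (`COc1cc2cc(C#N)ccc2c(OC)c1Oc1cc(NCCC2=CCCCC2)nc(Nc2ccc(C#N)cc2)n1`) gives > 125000 nM, also a limit, so it has no number of its own. For the measured compounds named here, the series so far therefore reads as the limit of > 125000 nM in this assay, at which 3 of the 3 values shown sit.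

Compound 4 (`COc1cc2cc(C#N)ccc2c(OC)c1Oc1cc(NCCCO)nc(Nc2ccc(C#N)cc2)n1`) differs from compound 3 as follows: hydroxymethyl in place of cyclohex-1-en-1-yl on a saturated chain carbon, two bonds along the chain from a nitrogen on an aromatic ring. In words, this is hydroxymethyl in place of cyclohex-1-en-1-yl on a saturated chain carbon, two bonds along the chain from a nitrogen on an aromatic ring.

The measured steps on this side chain are a step that the two limits leave unreadable from compound 1 to compound 2 and a step that the two limits leave unreadable from compound 1 to compound 3. None of them brings in hydroxymethyl. On the strength of a step that the two limits leave unreadable from compound 2 to compound 3, which also stays at the limit, no step beyond the scatter is expected in this assay, in either direction. The expected change is a number no higher from compound 3 to compound 4 (the limit leaves the size open). The estimate for compound 4 is 125000 nM, with an expected range of 50000 nM to 200000 nM.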

Compound 4, half-maximal cytotoxic concentration: 23500 nM
For compound 4 the middle estimate is 5.3-fold (0.73 log units) above the measured one; measured number outside the range, below it.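

Putting hydroxymethyl in place of cyclohex-1-en-1-yl on a saturated chain carbon, two bonds along the chain from a nitrogen on an aromatic ring, gives an at least 5.3-fold lower number from compound 3 to compound 4 (0.72 log units; beyond the scatter) in this assay, whereas the steps among compound 1, compound 2 and compound 3 cannot be read. The other two side chains show the same picture, with 3-hydroxypropyl in place of 1-propylbutyl giving an at least 5.3-fold lower number from compound 2 to compound 4 (0.72 log units; beyond the scatter) and 2-hydroxyethyl in place of tert-butyl giving an at least 5.3-fold lower number from compound 1 to compound 4 (0.72 log units; beyond the scatter). Among the compounds shown, a number below the limit appears only with the 3-hydroxypropyl chain of compound 4, while the others stay at the limit: the limit of > 125000 nM in this assay, at which 3 of the 4 values shown sit.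

Compound 4 loses the carbon ring and gains the hydroxymethyl in one change, so the compounds shown do not separate the two. They also leave open how an amine, a carboxylic acid or a methoxymethyl group in place of hydroxymethyl would read in this assay.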